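This account rests on a few compounds, and the source may have more. Where it says the series, first, only, none or still open, it means among the compounds named here.

Compound 1 `Cc1nc2c(OCc3ccccc3)cccn2c1N` stands highest of the three numbers in hand. In a functional assay on the whole organism with Canis familiaris (Canis lupus familiaris) as the target, at a dose of 8 mg/kg by the oral route (a lower number here means a weaker effect, a higher number a stronger effect of the compound at the dose given), compound 1 gives 96%. Compound 2 `Cc1nc2c(OCc3ccc(Cl)cc3)cccn2c1N` gives 92%, and compound 3 `Cc1nc2c(OCc3ccc(C(F)(F)F)cc3)cccn2c1N` gives 8%. The step of a number 4 percentage points lower from compound 1 to compound 2 (within the scatter) comes with chloro in place of hydrogen on an aromatic carbon, whereas the step of a number 88 percentage points lower from compound 1 to compound 3 (beyond the scatter) comes with trifluoromethyl in place of hydrogen on an aromatic carbon; between the two substituted compounds, a number 84 percentage points lower from compound 2 to compound 3 (beyond the scatter).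

Compound 4 `Cc1nc2c(OCc3ccsc3)cccn2c1N` differs from compound 1 as follows: thiophen-3-yl in place of phenyl on a saturated chain carbon bound to an oxygen on an aromatic ring. Among the measured compounds shown here, none of the measured steps exchanges the ring itself; they only alter what sits on the phenyl, and they show that one such alteration leaves the effect unchanged while another removes most of it. The swap of the ring is therefore untested ground, and a modest downward step from compound 1 is expected, of the order of a number 21 percentage points lower from compound 1 to compound 4 (beyond the scatter), with wide uncertainty. Compound 4 is estimated at 75%, in a range from 30% to 95%.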

Compound 4, a percentage reported as inhibition, in the whole organism at one dose (the size of the read-out at that dose, not a potency): 88%
The estimate for compound 4 lay 13 percentage points below the measured number; measured number inside the range.
By their numbers in this assay, from the lowest: compound 3; then compounds 4, 2 and 1 (each within the scatter of the next).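

In this assay, thiophen-3-yl can take the place of phenyl on this saturated chain carbon with a number 8 percentage points lower from compound 1 to compound 4 (within the scatter). The earlier compounds shown here changed only what sits on the phenyl, whereas this result shows that the ring itself can be exchanged, a six-membered carbon ring for a five-membered ring holding a sulfur, with no loss beyond the scatter at this single dose. No measured data explain why this exchange leaves the effect in place.

From the compounds shown here alone, whether a pyridin-3-yl or a saturated cyclohexyl ring at the same place would also keep the effect remains open, as does the outcome for thiophen-2-yl, where the ring is attached through a different carbon. Going by these compounds, it is also open whether compound 1 and compound 4 would still match at lower doses, where one of them could show a weaker effect than the other.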